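Oxanyl to methylpyrazolyl swap at the amine-bearing carbon

The source may report more compounds than this note shows. Statements on the series, on what has been measured and on what is new or still open speak of the compounds shown alone.

Measured so far:
compound 1 `COCc1ccc(-c2ccc3nnc(C(N)=O)c(N[C@@H](C)c4ccn(C)n4)c3c2)cn1`: 260 nM
compound 2 `C[C@H](Nc1c(C(N)=O)nnc2ccc(-c3ccc(OCCCN4CCCC4)nc3)cc12)C1CCOCC1`: 1.8 nM

In an assay on HT-29 cells for inhibition of Serine-protein kinase ATM (Homo sapiens), read by fluorescence, with a stated time of 1 h (on this read-out lower numbers stand for stronger inhibition and higher numbers for weaker inhibition), compound 2 gives the lower of the two numbers shown, and compound 1 stands a long way above it. Compound 3 `C[C@H](Nc1c(C(N)=O)nnc2ccc(-c3ccc(OCCCN4CCCC4)nc3)cc12)c1ccn(C)n1` keeps the rest of compound 2 and carries 1-methyl-1H-pyrazol-3-yl in place of oxan-4-yl on a saturated chain carbon bound to a nitrogen on an aromatic ring and a saturated chain carbon. Compound 1 and compound 2 differ in more than this one place, so the contribution of the swap alone cannot be read from them. The step expected for a 2.2-fold higher number from compound 2 to compound 3 (0.35 log units; beyond the scatter) is small, toward a higher number or none beyond the scatter. Compound 3 is estimated at 4 nM, within 1.5 nM to 15 nM.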

Compound 3, half-maximal inhibitory concentration in the Serine-protein kinase ATM assay: 1.1 nM
Compound 3: the middle estimate sits 3.6-fold (0.56 log units) above what was measured, outside the stated range (below it).
By their numbers in the Serine-protein kinase ATM assay, from the lowest: compounds 3 and 2 (each within the scatter of the next); then compound 1.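

On the saturated chain carbon, 1-methyl-1H-pyrazol-3-yl and oxan-4-yl are not told apart in the Serine-protein kinase ATM assay, with a 1.6-fold lower number from compound 2 to compound 3 (0.21 log units; within the scatter), or in a physicochemical assay for lipophilicity, using the shake flask method, measured as octanol-water partition, with a stated time of 30 min, at pH 7.4 (a higher number here means a more lipophilic compound, a lower number a more polar compound), where compound 2 gives 1.9 and compound 3 gives 1.8, with a number 0.10 log units lower from compound 2 to compound 3 (within the scatter). The large step lies on the aromatic carbon instead: with 3-(pyrrolidin-1-yl)propoxy in place of methoxymethyl, the Serine-protein kinase ATM assay gives a 240-fold lower number from compound 1 to compound 3 (2.37 log units; beyond the scatter). Nothing measured here explains either step.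

Open, from the compounds shown here alone, is whether oxan-4-yl tolerates methoxymethyl on the aromatic carbon as 1-methyl-1H-pyrazol-3-yl does in compound 1. Also open, going by these compounds, is how a shorter chain ending in a dimethylamino group, or a carboxylic acid, would compare with 3-(pyrrolidin-1-yl)propoxy.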